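Working notes: moving the methyl, compound 3 to compound 4

This account rests on a few compounds, and the source may have more. Where it says the series, first, only, none or still open, it means among the compounds named here.

Measured so far in a functional assay on K562 cells (Homo sapiens) for cytotoxicity, read by ELISA, with a stated time of 4 days (on this read-out lower numbers stand for stronger inhibition and higher numbers for weaker inhibition), on this series:
- compound 1 `Clc1ccc(-c2cc(-c3ccco3)cc(-c3ccc(Cl)s3)n2)cc1` gives 10500 nM
- compound 2 `Clc1ccc(-c2cc(-c3ccoc3)cc(-c3ccco3)n2)s1` gives 16200 nM
- compound 3 `Cc1ccccc1-c1cc(-c2ccoc2)cc(-c2ccc(Cl)s2)n1` gives 12300 nM

Compound 3 at 12300 nM lies within the scatter of both compound 1 and compound 2, so the three numbers form one group and give no ranking.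

The next compound is compound 4 `Cc1ccc(-c2cc(-c3ccoc3)cc(-c3ccc(Cl)s3)n2)cc1` and the change is 4-methylphenyl in place of 2-methylphenyl on an aromatic carbon in words 4-methylphenyl in place of 2-methylphenyl on an aromatic carbon. The place is next to the ring nitrogen, meta to a 5-chlorothiophen-2-yl group and meta to a furan-3-yl group.

Among the measured compounds shown here, one measured step touches this place. It is a 1.3-fold lower number from compound 2 to compound 3 (0.12 log units; within the scatter) for 2-methylphenyl in place of furan-2-yl, and even that exchange of whole groups stayed within the scatter. For the measured compounds named here, no measured pair compares 2-methylphenyl with 4-methylphenyl directly, so the evidence is indirect.

Going by the values given here, with only that step to go on, no change beyond the scatter is expected in this assay and neither direction is favoured. The expected step is a 1.1-fold lower number from compound 3 to compound 4 (0.05 log units; within the scatter) and it stays within the scatter. Compound 4 is estimated at 11000 nM with an expected range from 5500 nM to 22000 nM in this read-out.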

Compound 4, half-maximal inhibitory concentration: 17900 nM
For compound 4 the middle estimate is 1.6-fold (0.21 log units) below the measured one; low and high end bracket the measured number.
By their numbers in this assay, from the lowest: compounds 1, 3, 2 and 4 (each within the scatter of the next).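

In this assay, among the compounds shown here, the methyl shift gives the first direct comparison of 2-methylphenyl and 4-methylphenyl at this place next to the ring nitrogen (a 1.5-fold higher number from compound 3 to compound 4 (0.16 log units; within the scatter)), so moving the methyl around the phenyl ring does not separate the two compounds on this read-out. The exchange of furan-2-yl for 4-methylphenyl (a 1.1-fold higher number from compound 2 to compound 4 (0.04 log units; within the scatter)) adds a second whole-group step that stays within the scatter, as did the earlier exchange for 2-methylphenyl, so furan-2-yl and both methylphenyl isomers now form one group at this place, and no preferred group can be named from them. No supporting measurement accompanies these numbers that could account for this flat result.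

Still open is whether any group at this place can move the number beyond the scatter, since the groups shown here are only furan-2-yl and the two methylphenyl isomers, and a phenyl carrying an amine or a carboxylic acid, or a longer chain such as hexyl, would test a much wider change. Also open, as far as these compounds go, is how the number responds to single changes at the furan-3-yl and 5-chlorothiophen-2-yl groups, with this place held constant.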